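Amide nitrogen substituent in a phenoxyacetamide series

The source may hold more compounds than are shown below. What is called first, only, known or untested is meant among the compounds shown, and "the series" means these compounds.

Measured so far:
- compound 1, `Cc1ccc(OCC(=O)N(Cc2cccs2)c2ncccn2)cc1`: 3700 nM
- compound 2, `CCN(Cc1ccco1)C(=O)COc1ccc(C)cc1`: 489 nM
- compound 3, `CCN(Cc1cccs1)C(=O)COc1cc(C)ccc1O`: 24 nM

All three were tested in an assay on HEK293 cells for agonist activity at transient receptor potential cation channel subfamily M member 8 (Homo sapiens), read by fluorescence and calcium flux, with a stated time of 15 min; a higher number here means that more compound is needed for the effect, a lower number that less compound is needed. Compound 1 has the highest number of the three; compound 2 gives a number a good deal lower, and compound 3 gives the lowest, both differences lying beyond the usual scatter. Compound 2 and compound 3 each differ from compound 1 in more than one place, so no single change can be read from them.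

The next compound, compound 4, `Cc1ccc(OCC(=O)N(Cc2cccs2)C(C)C)cc1`, differs from compound 1 in one place only: isopropyl in place of pyrimidin-2-yl on an amide-type nitrogen. Compound 2 carries a short alkyl group on the amide-type nitrogen and gives 489 nM in this assay, which points toward a lower number for compound 4 than for compound 1. A drop beyond the scatter is expected, though the other differences present in compound 2 leave its size uncertain. The estimate implies a step of a 6.2-fold lower number from compound 1 to compound 4 (0.79 log units; beyond the scatter). Compound 4 is accordingly expected near 600 nM, within a range of 150 nM to 2500 nM.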

Compound 4, half-maximal effective concentration: 70 nM
Beside the measured number, compound 4's estimate is 8.6-fold (0.93 log units) above it; the whole stated range lies above it.
By their numbers in this assay, from the lowest: compound 3; then compound 4; then compound 2; then compound 1.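

In this assay, the substituent on the amide-type nitrogen is now the first place in the series where a single change can be read, and that change is large: isopropyl in place of pyrimidin-2-yl gives a 53-fold lower number from compound 1 to compound 4 (1.72 log units; beyond the scatter). The number at this position therefore depends strongly on the group it carries, and an open-chain group of 3 heavy atoms with no hydrogen-bond acceptors gives the lower number here, not the aromatic ring of 6 heavy atoms with 2 acceptors. Ring, size and acceptor count all change together in this one step, and no measurement is available to explain the drop.

Still open, from the compounds shown here alone, is which of these differences matters, since a phenyl or pyridin-2-yl group would keep a ring on this nitrogen while cyclopropyl or tert-butyl would vary the carbon group. The other compounds differ from compound 4 in more than one place, so no further steps can be read from them.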